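Adding a methyl to a nearly inactive compound

The source may report more compounds than this note shows. Statements on the series, on what has been measured and on what is new or still open speak of the compounds shown alone.

Values in a functional assay on HT-29 cells (Homo sapiens) for inhibition, read by luminescence and CellTiter-Glo, with a stated time of 10 h (a lower number here means that less compound is needed, a higher number that more compound is needed for the effect), for the measured compounds:
Compound 1 `CN1C(=O)[C@@H](NC(=O)c2n[nH]c(Cc3ccccc3)n2)COc2ncccc21` gives > 10000 nM as a limit
Compound 2 `CN1C(=O)[C@H](NC(=O)c2n[nH]c(Cc3ccccc3)n2)COc2ncccc21` gives > 10000 nM as a limit
Compound 3 `Cc1ccc2c(n1)OC[C@H](NC(=O)c1n[nH]c(Cc3ccccc3)n1)C(=O)N2C` gives 363 nM as a number

Compound 1 reads > 10000 nM in this assay and this is a limit, not a number. Two of the three values share that limit, so compound 1 has no exact place on the scale. Inverting its stereocentre gives a step that the two limits leave unreadable from compound 1 to compound 2 and therefore offers no guide here.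

Compound 4 `Cc1cnc2c(c1)N(C)C(=O)[C@@H](NC(=O)c1n[nH]c(Cc3ccccc3)n1)CO2` keeps the drawn configuration of compound 1 and carries methyl in place of hydrogen on an aromatic carbon. Among the measured compounds shown here, the one measured step of this kind is an at least 27-fold lower number from compound 1 to compound 3 (1.44 log units; beyond the scatter) and that step bears most directly on the question. For the measured compounds named here, in compound 3, however, the methyl stands on a different aromatic carbon, and no measured compound shows what the new place does. A step in the same direction is therefore expected in this assay but probably a smaller one, and a second reading at the limit remains possible. The estimated change is an at least 6.6-fold lower number from compound 1 to compound 4 (0.82 log units; beyond the scatter) and it carries wide uncertainty. For compound 4 the expected value is 1500 nM with an estimated range from 150 nM to 10000 nM in this assay.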

Compound 4, half-maximal effective concentration: 243 nM
The estimate for compound 4 lay 6.2-fold (0.79 log units) above the measured number; measured number inside the range.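

The methyl on the aromatic carbon two atoms from the ring nitrogen is enough on its own to bring the compound into the measurable range of this assay, with an at least 41-fold lower number from compound 1 to compound 4 (1.61 log units; beyond the scatter). Compound 3 had shown this only for a different aromatic carbon, through an at least 27-fold lower number from compound 1 to compound 3 (1.44 log units; beyond the scatter), so the same change now gives a large step at two places on this ring rather than at one, and here it does so with the drawn configuration of compound 1 kept. The starting value of compound 1, > 10000 nM, is a limit, so the full size of the step cannot be stated and only its lower bound is known: the limit of > 10000 nM in this assay, at which 2 of the 4 values shown sit.

The compounds shown leave open whether the gain belongs to the methyl itself, as an ethyl or a methoxy group at this same place would be needed to tell. They also leave open what inverting the stereocentre does once a methyl stands on the ring, as the only pair differing in configuration alone gives no readable step: the fact that compounds 1 and 2 differ only in the configuration as drawn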